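Swapping 4-(dimethylamino)phenyl for pyridin-3-yl on a carbonyl carbon

The source may report more compounds than this note shows. Statements on the series, on what has been measured and on what is new or still open speak of the compounds shown alone.

- compound 1 `Cc1cc(C)cc(C(=O)N(CC(=O)NCc2ccccc2)Cc2ccc(C(=O)Nc3cc(F)ccc3N)cc2)c1` measured at 5400 nM
- compound 2 `CN(C)c1ccc(C(=O)N(CC(=O)NCc2ccccc2)Cc2ccc(C(=O)Nc3ccccc3N)cc2)cc1` measured at 2400 nM
- compound 3 `Cc1cc(C)cc(CNC(=O)CN(CCCCCC(=O)Nc2ccccc2N)C(=O)c2cc(C)cc(C)c2)c1` measured at 5100 nM

In a functional assay on A2780 cells (Homo sapiens) for cytotoxicity, read by MTT assay, with a stated time of 72 h (on this read-out lower numbers stand for stronger inhibition and higher numbers for weaker inhibition), compound 2 gives the lowest of the three numbers (2400 nM), and its gaps to compound 3 and to compound 1 both lie beyond the scatter. Compound 1 and compound 3 sit within the scatter of each other.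

Compound 4 `Nc1ccccc1NC(=O)c1ccc(CN(CC(=O)NCc2ccccc2)C(=O)c2cccnc2)cc1` has yet to be measured. Relative to compound 2, it has pyridin-3-yl in place of 4-(dimethylamino)phenyl on a carbonyl carbon. Within the data shown here, no two measured compounds differ in only one place, so the series offers no direct precedent for this change. The three values do span a narrow range, however, with compound 2 (2400 nM) at the low end and compound 1 (5400 nM) at the high end. With compound 2 already lowest, a small move towards a higher number is expected in this assay, not clearly beyond the scatter. The expected step of a 1.7-fold higher number from compound 2 to compound 4 (0.22 log units; within the scatter) is therefore modest, and its direction remains uncertain. Compound 4 is estimated at 4000 nM (expected range 1800 nM to 9000 nM).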

Compound 4, half-maximal inhibitory concentration: 8900 nM
Compound 4: middle estimate off by 2.2-fold (0.35 log units), on the low side; low and high end bracket the measured number.
By their numbers in this assay, from the lowest: compound 2; then compounds 3, 1 and 4 (each within the scatter of the next).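

In this assay, among these compounds, the place on the carbonyl carbon whose other neighbour is the amide-type nitrogen proves sensitive to the group it carries: pyridin-3-yl in place of 4-(dimethylamino)phenyl gives a 3.7-fold higher number from compound 2 to compound 4 (0.57 log units; beyond the scatter), and this is the only comparison here in which two compounds differ in one place. The earlier compounds shown here could not show this, since each differed from the others in more than one place. The two groups have the same counts of hydrogen-bond donors and acceptors and the same lack of net charge, but they differ in heavy atoms and in their rings, and no measurement shown accounts for the higher number.

The compounds shown leave open whether the step follows from losing the dimethylamino group or from bringing in the ring nitrogen, a question that plain phenyl, 4-aminophenyl or 4-methoxyphenyl at this place could help to separate. Also open, on these data alone, is whether pyridin-4-yl or pyridin-2-yl would behave like pyridin-3-yl, and whether the same swap gives a similar step on a core carrying the fluorine of compound 1.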